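The source may hold more compounds than are shown below. What is called first, only, known or untested is meant among the compounds shown, and "the series" means these compounds.

Working notes on the bromoalkoxy series.

Compound 3 `COc1cc(/C=C/c2cc(/C=C/c3cc(OC)c(OC)c(OC)c3)nc(OCCCCCBr)n2)cc(OC)c1OC` and compound 1 `COc1cc(/C=C/c2cc(/C=C/c3cc(OC)c(OC)c(OC)c3)nc(OCCCCBr)n2)cc(OC)c1OC` share one core; compound 2 `COc1ccc(/C=C/c2cc(/C=C/c3ccc(OC)c(OC)c3)nc(OCCCCCCBr)n2)cc1OC` and the not yet measured compound 4 `COc1ccc(/C=C/c2cc(/C=C/c3ccc(OC)c(OC)c3)nc(OCCCCCBr)n2)cc1OC` share another. The difference between the two cores is not broken down here.

In a functional assay on NCI-H1299 cells (Homo sapiens) for cytotoxicity, read by fluorescence and resazurin assay, with a stated time of 48 h (a higher number here means a weaker inhibitor, a lower number a stronger inhibitor), compound 3 gives a limit, > 20000 nM, and not a number. Compound 1 also reaches only a limit, > 20000 nM. For compound 2 this assay likewise records a limit, > 20000 nM. All three sit at the limit of > 20000 nM in this assay, at which 3 of the 3 values shown sit, so the change bromo in place of bromomethyl on a saturated chain carbon, four bonds along the chain from an oxygen on an aromatic ring gives a step that the two limits leave unreadable from compound 3 to compound 1.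

The change from compound 2 to compound 4 is bromo in place of bromomethyl on a saturated chain carbon, five bonds along the chain from an oxygen on an aromatic ring. It is the same kind of change as that from compound 3 to compound 1, but the place differs: four bonds along the chain from the aromatic oxygen in one case, five bonds in the other, and the core differs as well.

Because compound 2 sits at the limit of > 20000 nM in this assay, at which 3 of the 3 values shown sit, and because compound 1 also sits at the limit of > 20000 nM in this assay, at which 3 of the 3 values shown sit, after the related change, compound 4 is expected to give a step that the limit leaves unreadable from compound 2 to compound 4 in this assay. The value expected for compound 4 is 30000 nM, most likely reported again as a limit, with a range from 15000 nM to 80000 nM.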

Compound 4, half-maximal inhibitory concentration: > 20000 nM
Compound 4: a limit, no number (the forecaster's own chance of this, stated with the estimate: 85%); the middle value is on the limit's open side.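

Compound 2 and compound 4 both give a limit and not a number, so no step can be read between them: the limit of > 20000 nM in this assay, at which 4 of the 4 values shown sit.

The compounds shown leave open whether the bromoalkoxy chain length or the core has any effect on potency in this assay, as none of them gives a number there.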